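The compounds below may be only part of what the source reports. "The series", "measured", "known", "first", "only" and "open" are said of these compounds alone.

Within the data shown here, compound 2 `Cc1ccc(OCC(=O)NNC(=O)c2cc3ccccc3oc2=O)c(C(=O)c2ccccc2)c1` gives 78400 nM in a functional assay on Ehrlich cells (Mus musculus) for cytotoxicity, read by MTT assay, with a stated time of 48 h (a lower number here means a stronger inhibitor, a higher number a weaker inhibitor), the highest of the two numbers so far, with compound 1 `Cc1ccc(OCC(=O)NNC(=O)c2cc3ccccc3oc2=O)c(C(=O)c2cccc(Cl)c2)c1` at 64900 nM, within the scatter of it. Compound 3 `Cc1ccc(OCC(=O)NNC(=O)c2cc3ccccc3oc2=O)c(C(=O)c2ccccc2Cl)c1` differs from compound 2 by chloro in place of hydrogen on an aromatic carbon. Among the measured compounds shown here, the only measured step that concerns a chloro on the same six-membered aromatic ring of carbon only, a 1.2-fold higher number from compound 1 to compound 2 (0.08 log units; within the scatter), stayed within the scatter. On that basis no step beyond the scatter is expected here, and the estimated step is a 1.1-fold lower number from compound 2 to compound 3 (0.04 log units; within the scatter). Compound 3 is therefore expected to give 72000 nM, with a range of 32000 nM to 160000 nM.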

Compound 3, half-maximal inhibitory concentration: 45200 nM
Compound 3: middle estimate off by 1.6-fold (0.20 log units), on the high side, and the stated range covers the measured number.
By their numbers in this assay, from the lowest: compounds 3, 1 and 2 (each within the scatter of the next).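

In this assay, among these compounds, chloro placed on the aromatic carbon ortho to a large group gives a 1.7-fold lower number from compound 2 to compound 3 (0.24 log units; within the scatter), so this position, like the one carrying chloro in compound 1, shows no step beyond the scatter. Replacing 3-chlorophenyl with 2-chlorophenyl gives a 1.4-fold lower number from compound 1 to compound 3 (0.16 log units; within the scatter), so the two chloro placements are not separated in these data. No measured evidence bears on the cause of these numbers. As far as these compounds go, whether an amine, a carboxylic acid or a methoxy group on this ring would give a step beyond the scatter remains open.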